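Swapping morpholine for pyrrolidine on inactive chromone dithiocarbamates

The compounds below may be only part of what the source reports. "The series", "measured", "known", "first", "only" and "open" are said of these compounds alone.

Of the compounds shown here, three have been tested in a functional assay on MDA-MB-435S cells (Homo sapiens) for antiproliferative activity, read by MTT assay, with a stated time of 72 h (a higher number here means a weaker inhibitor, a lower number a stronger inhibitor), and none of them gave a number. Compound 3 `O=c1cc(CSC(=S)N2CCOCC2)oc2cc(Cl)ccc12` reaches only a limit of the assay, reported as > 25000 nM. Compound 1 `O=c1cc(CSC(=S)N2CCCC2)oc2cc(Cl)ccc12`, which carries pyrrolidin-1-yl in place of morpholin-4-yl on a thiocarbonyl carbon, likewise stops at a limit, > 25000 nM. The step from compound 3 to compound 1 is therefore a step that the two limits leave unreadable from compound 3 to compound 1: with both values sitting at a limit, its size cannot be read. Compound 2 `COc1ccc2occ(CSC(=S)N3CCOCC3)c(=O)c2c1`, built on a different core, also returns a limit in this assay, > 40000 nM. How the core of compound 2 differs from the core of compound 3 is not broken down here.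

Compound 4 `COc1ccc2occ(CSC(=S)N3CCCC3)c(=O)c2c1` has not yet been measured. It differs from compound 2 by the same change already seen between compound 3 and compound 1: pyrrolidin-1-yl in place of morpholin-4-yl on a thiocarbonyl carbon. For the measured compounds named here, since every value so far is a limit, two of them at the limit of > 25000 nM in this assay, at which 2 of the 3 values shown sit, and one at the limit of > 40000 nM in this assay, at which 1 of the 3 values shown sits, there is no measured step to carry over, only the observation that the change did not lift compound 1 to a readable value. The step from compound 2 to compound 4 is accordingly expected to be small, a step that the limit leaves unreadable from compound 2 to compound 4, and compound 4 is expected to remain weak in this assay, around 50000 nM, most likely reported again only as a limit.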

Compound 4, half-maximal inhibitory concentration: 1800 nM
Compound 4: middle estimate off by 28-fold (1.44 log units), on the high side; measured number below the stated range.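

In this assay, pyrrolidin-1-yl in place of morpholin-4-yl on a thiocarbonyl carbon gives an at least 22-fold lower number from compound 2 to compound 4 (1.34 log units; beyond the scatter), and the true step may be larger still, since the starting value is a limit: the limit of > 40000 nM in this assay, at which 1 of the 4 values shown sits.

The same change on the core of compound 3 yields no readable step, since compound 3 and compound 1 both stop at one limit: the limit of > 25000 nM in this assay, at which 2 of the 4 values shown sit.

So the change turned an inactive compound into one with a measured value on one core but not on the other, which shows that a gain seen on one core cannot simply be assumed on another, though with a single pair per core it does not show why the two cores part ways or how large any effect on the core of compound 3 might be.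

As far as these compounds go, it remains open whether pyrrolidin-1-yl is special or whether a piperidin-1-yl ring or an open-chain diethylamino group on the same thiocarbonyl carbon would also give a measurable value on the core of compound 4. For the compounds shown here, also open is which feature of the core matters, since the cores of compound 3 and compound 2 differ in more than one way, and no compound here separates the chloro group from the methoxy group.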